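A few compounds are considered here, and "the series" means these few. Any claim that something is new, unique, unknown or untested is made for them only; others in the source may bear on it.

Working notes on the series. Compound 1 `O=C1O[C@@H](CO)CN1c1ccc(-n2cc(-c3ccccn3)cn2)c(F)c1` carries the shared core with hydroxy on a saturated chain carbon bound to a saturated ring carbon; in a physicochemical assay for solubility, read by HPLC, with a stated time of 24 h (on this read-out lower numbers stand for lower solubility and higher numbers for higher solubility), compound 1 gives 56400 nM. Compound 2 `COC(=O)CC1CCN(C[C@H]2CN(c3ccc(-n4cc(-c5ccccn5)cn4)c(F)c3)C(=O)O2)CC1` gives 92100 nM, and compound 3 `O=C1O[C@@H](CN2CCC(O)CC2)CN1c1ccc(-n2cc(-c3ccccn3)cn2)c(F)c1` gives 45900 nM. All three numbers sit within the scatter of one another: a 1.2-fold lower number from compound 1 to compound 3 (0.09 log units; within the scatter), a 2.0-fold lower number from compound 2 to compound 3 (0.30 log units; within the scatter), and a 1.6-fold higher number from compound 1 to compound 2 (0.21 log units; within the scatter). Compound 3 therefore stands level with compound 1 and compound 2 on these numbers, none of the three set apart.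

The next step goes from compound 3 to compound 4 `CCC(=O)NC[C@H]1CN(c2ccc(-n3cc(-c4ccccn4)cn3)c(F)c2)C(=O)O1`. The change is propanoylamino in place of 4-hydroxypiperidin-1-yl on a saturated chain carbon bound to a saturated ring carbon. The two measured steps at the same place, a 1.2-fold lower number from compound 1 to compound 3 (0.09 log units; within the scatter) and a 2.0-fold lower number from compound 2 to compound 3 (0.30 log units; within the scatter), both fell within the scatter, so swapping the group at this position has so far moved nothing beyond the scatter. For the measured compounds named here, no measured step brings in an amide at this place. On that basis compound 4 is expected to show no step beyond the scatter in this assay, with a 1.1-fold lower number from compound 3 to compound 4 (0.06 log units; within the scatter) as the expected change. The estimate for compound 4 is 40000 nM, within 15000 nM to 100000 nM.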

Compound 4, solubility: 147000 nM
Compound 4: the middle estimate sits 3.7-fold (0.57 log units) below what was measured; measured number outside the range, above it.
By their numbers in this assay, from the lowest: compounds 3, 1, 2 and 4 (each within the scatter of the next, the first and the last beyond it).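

In this assay, this position now shows steps beyond the scatter: propanoylamino in place of 4-hydroxypiperidin-1-yl (a 3.2-fold higher number from compound 3 to compound 4 (0.51 log units; beyond the scatter)) and propanoylamino in place of hydroxy (a 2.6-fold higher number from compound 1 to compound 4 (0.42 log units; beyond the scatter)), both modest, where the earlier swaps at this place stayed within it. Propanoylamino in place of 4-((methoxycarbonyl)methyl)piperidin-1-yl (a 1.6-fold higher number from compound 2 to compound 4 (0.20 log units; within the scatter)) does not leave the scatter, so compound 2 goes against any reading of propanoylamino as set apart from every other group at this place. No measurement bearing on the origin of these steps is available.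

The compounds shown do not separate the entry of the amide from the departure of the piperidine ring. A plain chain amine, a longer acyl chain or a sulfonamide on the same saturated chain carbon would test that separation.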